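The source may hold more compounds than are shown below. What is called first, only, known or untested is meant among the compounds shown, and "the series" means these compounds.

Compound 2 `CCC(C)CN(c1ccnc(Nc2ccc(C#N)cc2)n1)c1c(F)cc(-c2ccc(C#N)cc2)cc1F` stands at a limit: in an ADME assay on MT4 cells (Homo sapiens) for cytotoxicity, read by MTT assay, with a stated time of 5 days (on this read-out higher numbers stand for lower toxicity in this test and lower numbers for higher toxicity in this test), compound 2 gives > 255000 nM, which is a limit of the assay and not a number. Compound 1 `CCCCN(c1ccnc(Nc2ccc(C#N)cc2)n1)c1c(F)cc(-c2ccc(C#N)cc2)cc1F` gives 211000 nM in this assay. Compound 3 `N#Cc1ccc(Nc2nccc(N(CC3CCCC3)c3c(F)cc(-c4ccc(C#N)cc4)cc3F)n2)cc1` also sits at a limit, giving > 247000 nM in this assay. Compound 4 `CC(=O)N(c1ccnc(Nc2ccc(C#N)cc2)n1)c1c(F)cc(-c2ccc(C#N)cc2)cc1F` differs from compound 2 by acetyl in place of 2-methylbutyl on a nitrogen on an aromatic ring. The measured steps of an at least 1.2-fold higher number from compound 1 to compound 2 (0.08 log units; that floor lies within the scatter) and a step that the two limits leave unreadable from compound 2 to compound 3 each swap one saturated chain for another and do not bring in an acetyl group, so none of them bears directly on this change, and both were small or unreadable. No step beyond the scatter is therefore expected, an at least 1.1-fold lower number from compound 2 to compound 4 (0.04 log units; that floor lies within the scatter). Compound 4 is estimated at 230000 nM, with a range from 100000 nM to 300000 nM.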

Compound 4, half-maximal cytotoxic concentration: > 268000 nM
Compound 4: no number, only a limit; the forecaster's own chance of this, stated with the estimate: 50%; at least 1.1-fold (0.06 log units) between middle value and limit.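

Compound 4 shows that this nitrogen on an aromatic ring can carry acetyl instead of a saturated chain and the read-out still ends at a limit of the assay, not a number: the limit of > 268000 nM in this assay, at which 1 of the 4 values shown sits. Set against butyl, acetyl gives an at least 1.2-fold higher number from compound 1 to compound 4 (0.10 log units; that floor lies within the scatter). The steps to compound 4 from compound 2 and from compound 3 cannot be read.

From the compounds shown here alone, how far the true values of these three compounds lie beyond their limits stays open. So does whether an amine or a carboxylic acid on this nitrogen would give a readable number.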